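This account rests on a few compounds, and the source may have more. Where it says the series, first, only, none or still open, it means among the compounds named here.

Compound 1, `O=C(O)C(Sc1nc(Cl)cc(Nc2cccc(Cl)c2)n1)c1cccc2ccccc12`, gives 700 nM in an assay on isolated protein for inhibition of Polyunsaturated fatty acid 5-lipoxygenase (Homo sapiens); a lower number here means a stronger inhibitor, a higher number a weaker inhibitor.
Compound 2, `CCCCNc1cc(Cl)nc(SC(C(=O)O)c2cccc3ccccc23)n1`, gives 2400 nM in this assay.

Going by the values given here, of these two numbers compound 2 stands highest, that is, it is the weaker inhibitor; its only neighbour is compound 1. Compound 3, `O=C(O)C(Sc1nc(Cl)cc(Nc2ccc(F)cc2)n1)c1cccc2ccccc12`, has not yet been measured in this assay. It differs from compound 2 in a single place: 4-fluorophenyl in place of butyl on a nitrogen on an aromatic ring. Among the compounds with values here, only one measured step bears on this change, and it runs the opposite way: going from an aryl group on that nitrogen to butyl gave a 3.4-fold higher number from compound 1 to compound 2 (0.54 log units; beyond the scatter), a modest rise beyond the scatter. Restoring an aryl group, here one carrying fluorine rather than chlorine, is therefore expected to lower the number again by a similar amount, so the expected step is a 3.0-fold lower number from compound 2 to compound 3 (0.48 log units; beyond the scatter). Compound 3 is estimated at 800 nM, with a likely range from 300 nM to 2000 nM.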

Compound 3, half-maximal inhibitory concentration: 3100 nM
Compound 3: the middle estimate sits 3.9-fold (0.59 log units) below what was measured, and the stated range ends below it.
By their numbers in this assay, from the lowest: compound 1; then compounds 2 and 3 (each within the scatter of the next).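

In this assay, having an aryl group on this nitrogen is not enough to keep the number low: 4-fluorophenyl in place of butyl gives a 1.3-fold higher number from compound 2 to compound 3 (0.11 log units; within the scatter) and so cannot be told apart from butyl here. The identity of the aryl group does matter, since 4-fluorophenyl in place of 3-chlorophenyl gives a 4.4-fold higher number from compound 1 to compound 3 (0.65 log units; beyond the scatter) and leaves compound 1 as the only one of the three set apart from the others. Nothing measured here explains this gap between the two aryl groups.

These two aryl groups differ in both their halogen and its place on the ring, so the compounds shown cannot separate those two changes. As far as these compounds go, how a plain phenyl group or a benzyl group on this nitrogen would compare also remains open.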